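The source may hold more compounds than are shown below. What is called first, only, known or untested is meant among the compounds shown, and "the series" means these compounds.

Three compounds have been measured in a functional assay on T47D cells (Homo sapiens) for cytotoxicity, read by MTT assay, with a stated time of 2 days; a higher number here means a weaker inhibitor, a lower number a stronger inhibitor:

compound 1 `Cc1ccc2nc(-c3ccccc3N(C)C)[nH]c(=O)c2c1` gives 26700 nM;
compound 2 `COc1cccc(-c2nc3ccc(N4CCCCC4)cc3c(=O)[nH]2)c1OC` gives 10400 nM;
compound 3 `Cc1ccc2c(=O)[nH]c(-c3ccccc3C)nc2c1` gives > 50000 nM.

The value for compound 3 is a limit of this assay and not a number, a position that the limit of > 50000 nM in this assay, at which 1 of the 3 values shown sits, records. Compound 3 therefore stands at the weak edge of what has been measured, whereas compound 1 and compound 2 each give a measured number within the range of this assay.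

The unmeasured compound 4 `Cc1ccc2c(=O)[nH]c(-c3ccccc3OC(F)(F)F)nc2c1` differs from compound 3 in one place: trifluoromethoxy in place of methyl on an aromatic carbon. Within the data shown here, no step between two measured compounds of this set is available to calibrate the change, so its size can only be estimated from the general picture: the shared core has so far given weak values throughout, and the change keeps the same ring pattern. Compound 4 is expected to give about 35000 nM in this assay, with a range of 10000 nM to 60000 nM. The expected step of an at least 1.4-fold lower number from compound 3 to compound 4 (0.15 log units; that floor lies within the scatter) is thus a modest move toward a measurable value, with a real chance that compound 4 again returns only a limit.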

Compound 4, half-maximal inhibitory concentration: > 50000 nM
Compound 4 ended at the assay's limit; the forecaster's own chance of this, stated with the estimate: 45%; at least 1.4-fold (0.15 log units) between middle value and limit.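

In this assay, compound 3 and compound 4 both end at a limit and not at a number, so no step can be read between them: the limit of > 50000 nM in this assay, at which 2 of the 4 values shown sit.

The compounds shown leave open whether trifluoromethoxy in place of methyl changes the value in this assay at all.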